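Replacing 4-hydroxypiperidin-1-yl with methylamino in compound 3

This account rests on a few compounds, and the source may have more. Where it says the series, first, only, none or still open, it means among the compounds named here.

Compound 1 `Nc1noc2ccc(-n3nc(C(F)(F)F)c4c3C(=O)N(c3ccc(-c5ccccc5CN5CCCC5)cc3F)CC4)cc12`: 85%
Compound 2 `Nc1noc2ccc(-n3nc(C(F)(F)F)c4c3C(=O)N(c3ccc(-c5ccccc5CN5CCCC5)cc3)CC4)cc12`: 37%
Compound 3 `Nc1noc2ccc(-n3nc(C(F)(F)F)c4c3C(=O)N(c3ccc(-c5ccccc5CN5CCC(O)CC5)cc3)CC4)cc12`: 102%

These values come from an in vivo ADME assay on the whole organism for pharmacokinetics, with Canis familiaris (Canis lupus familiaris) as the target; on this read-out higher numbers stand for higher oral bioavailability and lower numbers for lower oral bioavailability. Compound 3 stands highest of the three, beyond the scatter from both others. Compound 4 `CNCc1ccccc1-c1ccc(N2CCc3c(C(F)(F)F)nn(-c4ccc5onc(N)c5c4)c3C2=O)cc1` differs from it by methylamino in place of 4-hydroxypiperidin-1-yl on a saturated chain carbon bound to an aromatic carbon. The closest measured step sits at that same place: a number 65 percentage points higher from compound 2 to compound 3 (beyond the scatter). The other step, a number 48 percentage points lower from compound 1 to compound 2 (beyond the scatter), concerns fluoro on an aromatic carbon and bears only loosely. Among the measured compounds shown here, no measured compound carries methylamino, so the uncertainty is wide. Even so, a large drop in this assay is expected. The expected step is a number 47 percentage points lower from compound 3 to compound 4 (beyond the scatter). Compound 4 is estimated at 55%, with an expected range of 25% to 90%.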

Compound 4, oral bioavailability: 67%
Compound 4: the middle estimate sits 12 percentage points below what was measured, within the range that was stated.
By their numbers in this assay, from the lowest: compound 2; then compound 4; then compound 1; then compound 3.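

In this assay, the place on a saturated chain carbon bound to an aromatic carbon has now taken three amines, and methylamino stands apart from both: a number 35 percentage points lower from compound 3 to compound 4 (beyond the scatter) and a number 30 percentage points higher from compound 2 to compound 4 (beyond the scatter). A ring is therefore not needed here to exceed the pyrrolidin-1-yl compound, and group size does not order the three, since both the largest and the smallest group exceed it. Nothing given here explains this order.

On these data alone, it remains open whether the hydroxyl or the six-membered ring lifts compound 3, which piperidin-1-yl could separate. Where dimethylamino would stand also remains open.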